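Amine exchange at the chain carbon: from compound 2 to compound 3

The source may hold more compounds than are shown below. What is called first, only, known or untested is meant among the compounds shown, and "the series" means these compounds.

In a functional assay on SMMC-7721 cells (Homo sapiens) for antiproliferative activity, read by MTT assay, with a stated time of 48 h (a lower number here means a stronger inhibitor, a higher number a weaker inhibitor), compound 1 `CC(C)=CCC[C@]1(C)/C=C/[C@@H](OC(=O)C=C(C)C)[C@](C)(O)/C=C/C(=O)/C(CCl)=C\C1` gives 840 nM and compound 2 `CC(C)=CCC[C@]1(C)/C=C/[C@@H](OC(=O)C=C(C)C)[C@](C)(O)/C=C/C(=O)/C(CN(C)C)=C\C1` gives 820 nM. For the measured compounds named here, compound 2 therefore stands level with compound 1, its only measured neighbour.

Compound 3 `CC(C)=CCC[C@]1(C)/C=C/[C@@H](OC(=O)C=C(C)C)[C@](C)(O)/C=C/C(=O)/C(CN(C(C)C)C(C)C)=C\C1` keeps the shared core and carries diisopropylamino in place of dimethylamino on a saturated chain carbon bound to a double-bonded ring carbon.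

Going by the values given here, only one measured step bears on this place: a 1.0-fold lower number from compound 1 to compound 2 (0.01 log units; within the scatter), with dimethylamino in place of chloro. Among the compounds with values here, no measured compound carries diisopropylamino, so this single step gives only weak guidance. No shift beyond the scatter is expected in this assay. The estimated step is a 1.2-fold higher number from compound 2 to compound 3 (0.09 log units; within the scatter). In this assay, the expected value for compound 3 is 1000 nM, with an estimated range of 450 nM to 2400 nM.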

Compound 3, half-maximal inhibitory concentration: 340 nM
Compound 3: the middle estimate sits 2.9-fold (0.47 log units) above what was measured, outside the stated range (below it).
By their numbers in this assay, from the lowest: compound 3; then compounds 2 and 1 (each within the scatter of the next).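

In this assay, this chain carbon now shows a response to the choice of amine: diisopropylamino in place of dimethylamino gives a 2.4-fold lower number from compound 2 to compound 3 (0.38 log units; beyond the scatter) and so moves the number beyond the scatter, which the earlier exchange of chloro for dimethylamino did not do. Measured against the chloro compound, diisopropylamino gives a 2.5-fold lower number from compound 1 to compound 3 (0.39 log units; beyond the scatter), so at this place the groups on the nitrogen separate the compounds, while an amine as such does not. No evidence here accounts for this step.

Two amines at this place are too few to set a trend, and compound 3 is the only one of the three that stands apart. From the compounds shown here alone, whether diethylamino would fall with dimethylamino or with diisopropylamino remains open, as does the outcome for cyclic amines such as piperidine or morpholine.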